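The compounds below may be only part of what the source reports. "The series", "measured", "known", "first", "only" and "open" are said of these compounds alone.

Measured so far in a functional assay on P388 cells (Mus musculus) for inhibition; a lower number here means a stronger inhibitor, a higher number a weaker inhibitor:

- compound 1 `O=C1CCCCC/C1=C\c1ccccc1` gives > 50000 nM, a limit of the assay
- compound 2 `O=C1CCCCC/C1=C\c1cccc(Cl)c1` gives 25700 nM
- compound 3 `Cc1cccc(/C=C2\CCCCCC2=O)c1` gives 29800 nM

Compound 3 carries a methyl group and compound 2 a chloro group at the same place on the shared core. Their numbers cannot be told apart, with a 1.2-fold higher number from compound 2 to compound 3 (0.06 log units; within the scatter). Both are compared with compound 1 only through its limit, which gives an at least 1.9-fold lower number from compound 1 to compound 2 (0.28 log units; that floor lies within the scatter) and an at least 1.6-fold lower number from compound 1 to compound 3 (0.22 log units; that floor lies within the scatter). Neither of these floors shows a step beyond the scatter.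

The next step leads to compound 4 `O=C1CCCCC/C1=C\c1cccc([N+](=O)[O-])c1`, with nitro in place of methyl on an aromatic carbon. Among the compounds with values here, no measured compound in this small set carries nitro, so the evidence is indirect. The closest guide is the exchange of methyl for chloro at the same place, seen in a 1.2-fold higher number from compound 2 to compound 3 (0.06 log units; within the scatter). On that single exchange, no step beyond the scatter is expected in this assay, and no direction can be assigned with confidence. The estimated change is a 1.2-fold lower number from compound 3 to compound 4 (0.08 log units; within the scatter). For compound 4 the expected value is 25000 nM, with an estimated range of 11000 nM to 50000 nM.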

Compound 4, half-maximal inhibitory concentration: 23600 nM
Compound 4: the middle estimate sits 1.1-fold (0.03 log units) above what was measured, within the range that was stated.
By their numbers in this assay, from the lowest: compounds 4, 2 and 3 (each within the scatter of the next). At a limit, above all of these: compound 1.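

On an aromatic carbon of the shared core, nitro brings more heavy atoms than methyl and hydrogen-bond acceptors that methyl lacks, yet in this assay its number cannot be told apart from that of methyl (a 1.3-fold lower number from compound 3 to compound 4 (0.10 log units; within the scatter)) or chloro (a 1.1-fold lower number from compound 2 to compound 4 (0.04 log units; within the scatter)). Against the hydrogen of compound 1, nitro gives the first floor in the series that lies beyond the scatter (an at least 2.1-fold lower number from compound 1 to compound 4 (0.32 log units; beyond the scatter)), but this does not set nitro apart from chloro or methyl, whose floors lie only just within it. Compound 1 stands at a limit of the assay, so this step gives a floor and not a size: the limit of > 50000 nM in this assay, at which 1 of the 4 values shown sits.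

On these data alone, whether an amine, a hydroxyl or a carboxylic acid at this place would stay level with nitro, chloro and methyl in this assay remains open. All the substituted compounds shown carry their group at this one place, so the same groups elsewhere on the aromatic ring, and any change to the rest of the shared core, also remain open.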